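Chlorine and a Longer Ether on the Amide Aryl

The source may report more compounds than this note shows. Statements on the series, on what has been measured and on what is new or still open speak of the compounds shown alone.

Compound 1, `COc1ccccc1NC(=O)CN1CCN(S(=O)(=O)N2CCC(C)CC2)CC1`, is an amide whose aryl group is a 2-methoxyphenyl. In an assay on HEK293 cells for inhibition of potassium channel subfamily T member 1 (Homo sapiens), read by thallium flux (on this read-out lower numbers stand for stronger inhibition and higher numbers for weaker inhibition), compound 1 returned only a limit, > 10000 nM, so its position is known just as a bound: it sits at the limit of > 10000 nM in this assay, at which 1 of the 2 values shown sits, and no number can be given for it. Compound 2, `COc1ccc(Cl)cc1NC(=O)CN1CCN(S(=O)(=O)N2CCC(C)CC2)C[C@@H]1C`, differs from compound 1 in more than one place, so the pair does not form a single step; in this assay compound 2 gives 3500 nM. Compound 3, `CCOc1ccc(Cl)cc1NC(=O)CN1CCN(S(=O)(=O)N2CCC(C)CC2)CC1`, carries 5-chloro-2-ethoxyphenyl in place of 2-methoxyphenyl on an amide-type nitrogen. Because compound 1 sits at the limit of > 10000 nM in this assay, at which 1 of the 2 values shown sits, any gain for compound 3 must be sizeable to appear as a number at all. With compound 2 showing 3500 nM while also bearing a chlorine-substituted aryl group, some improvement is expected, though compound 2 differs elsewhere too, so the comparison is loose. The step from compound 1 to compound 3 is expected to be an at least 1.6-fold lower number from compound 1 to compound 3 (0.22 log units; that floor lies within the scatter), toward stronger inhibition, yet it may stay within the scatter or at the limit. Compound 3 is therefore estimated at 6000 nM, with a range from 2000 nM to 20000 nM.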

Compound 3, half-maximal inhibitory concentration: 7100 nM
Beside the measured number, compound 3's estimate is 1.2-fold (0.07 log units) below it; the measured number falls inside the stated range.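

In this assay compound 1 gives > 10000 nM as a limit and not a number. Among the compounds shown here, with 5-chloro-2-ethoxyphenyl in place of 2-methoxyphenyl on the amide-type nitrogen, compound 3 gives 7100 nM as a true reading, so this place on the amide can take the larger aryl group and still give a value on the scale, which the earlier compounds did not show for a single change. The change amounts to an at least 1.4-fold lower number from compound 1 to compound 3 (0.14 log units; that floor lies within the scatter) and only that floor is known, so the real step could be larger, because one end of it is not a number: the limit of > 10000 nM in this assay, at which 1 of the 3 values shown sits.

The change brings in the chlorine and the longer ethoxy chain together, so the compounds shown cannot say whether either one alone would give a reading in this assay or whether both are needed. Also open, from the compounds shown here alone, is whether a bromine in place of the chlorine, or a propoxy chain in place of the ethoxy, would lower the number further on the same core.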